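The compounds below may be only part of what the source reports. "The series", "measured", "known", "first", "only" and "open" are said of these compounds alone.

Working notes on the series.

Going by the values given here, compound 1 `COc1cc(/C=C/C(=O)/C=C(/C=C/c2ccc(O)c(OC)c2)NCCCO)ccc1O` is one of two compounds measured in a functional assay, read by spectrophotometry, with a stated time of 30 min; a higher number here means that more compound is needed for the effect, a lower number that less compound is needed. Compound 1 gives 27600 nM, the lowest of the two numbers recorded in this assay. The other measured compound is compound 2 `COCCCNC(=C\C(=O)/C=C/c1ccc(O)cc1)/C=C/c1ccc(O)cc1`, which in this assay gives 130000 nM, a number that stands clearly apart from that of compound 1, beyond the usual scatter. Compound 2 differs from compound 1 in more than one place, so the two values alone say nothing about any single part of the structure.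

The next compound in line is compound 3 `COCCCNC(=C\C(=O)/C=C/c1ccc(O)c(OC)c1)/C=C/c1ccc(O)c(OC)c1`, which has not yet been measured in this assay. Compound 3 differs from compound 1 in one place only: methyl in place of hydrogen on an oxygen on a saturated carbon.

Among the compounds with values here, no step between measured compounds isolates this change. The expectation is a small step in this assay, if any, since a change of a single carbon on the chain end offers no basis for a large shift; the estimated step of a 1.3-fold higher number from compound 1 to compound 3 (0.10 log units; within the scatter) is expected to lie within the usual scatter. Compound 3 is expected to give about 35000 nM, in a range from 12000 nM to 100000 nM.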

Compound 3, half-maximal effective concentration in the functional assay: 29500 nM
Estimate against measurement, compound 3: 1.2-fold (0.07 log units) above, and the stated range covers the measured number.
By their numbers in the functional assay, from the lowest: compounds 1 and 3 (each within the scatter of the next); then compound 2.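

Methyl in place of hydrogen on an oxygen on a saturated carbon is the first single change that can be read in this series, and in the functional assay the step is small, a 1.1-fold higher number from compound 1 to compound 3 (0.03 log units; within the scatter), so hydroxy and methoxy at the chain end cannot be told apart in this read-out. In a physicochemical assay for solubility, using the shake flask method, in phosphate buffer, with a stated time of 24 h, at pH 6.8 (a lower number here means a less soluble compound, a higher number a more soluble compound), compound 1 gives 56300 nM and compound 3 gives 9660 nM, so the two compounds that match in the functional assay separate clearly in the physicochemical assay. The same change from hydroxy to methoxy at this position therefore goes with lower solubility, with no matching shift in the functional read-out: the measured solubility of compound 1, 56300 nM, and of compound 3, 9660 nM, a 5.8-fold lower number (0.77 log units; beyond the scatter)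

Going by these compounds, it remains open whether an amine, a carboxylic acid or a longer chain at this chain end would keep the number in the functional assay close to that of compound 1 while giving a solubility as high as that of compound 1 or higher. This single pair also cannot tell whether the same change would behave alike on the core of compound 2.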